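The source may hold more compounds than are shown below. What is called first, only, known or untested is meant among the compounds shown, and "the series" means these compounds.

Measured so far in a physicochemical assay for lipophilicity; a lower number here means a more polar compound, a higher number a more lipophilic compound:
- compound 1 `C[C@H]1CC[C@@H]2[C@@H](OC(=O)[C@]23CC(c2ccccc2[N+](=O)[O-])=NO3)[C@]2(C)C(=O)C=C[C@@]12O` gives 1.37
- compound 2 `COc1cc(C2=NO[C@]3(C2)C(=O)O[C@@H]2[C@H]3CC[C@H](C)[C@]3(O)C=CC(=O)[C@@]23C)ccc1O` gives 0.75

Compound 2 holds the lower of the two numbers. Compound 3 `Cc1cccc(C2=NO[C@]3(C2)C(=O)O[C@@H]2[C@H]3CC[C@H](C)[C@]3(O)C=CC(=O)[C@@]23C)c1` differs from it in one place, with 3-methylphenyl in place of 4-hydroxy-3-methoxyphenyl on a carbon with a double bond to nitrogen and no other change. For the measured compounds named here, one measured step bears on this, and it brought the same 4-hydroxy-3-methoxyphenyl in: a number 0.62 log units lower from compound 1 to compound 2 (beyond the scatter) as a modest step. Removing that group from compound 2 is therefore expected to give a modest step upward in this assay of similar size. The estimated change is a number 0.85 log units higher from compound 2 to compound 3 (beyond the scatter) on this single precedent. For compound 3 the expected value is 1.6 with an estimated range from 1.15 to 2.1 as the working figure.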

Compound 3, partition coefficient: 1.86
The estimate for compound 3 lay 0.26 log units below the measured number; low and high end bracket the measured number.
By their numbers in this assay, from the lowest: compound 2; then compound 1; then compound 3.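

In this assay, the group on the carbon with a double bond to nitrogen now shifts the number in both directions from compound 1: 3-methylphenyl in place of 2-nitrophenyl gives a number 0.49 log units higher from compound 1 to compound 3 (beyond the scatter), and 3-methylphenyl in place of 4-hydroxy-3-methoxyphenyl gives the large a number 1.11 log units higher from compound 2 to compound 3 (beyond the scatter). Compound 1 therefore lies between compound 2 and compound 3 in this series. Nothing available explains the size of either step.

Going by these compounds, the hydroxy and methoxy groups leave together, so the share of each remains open. On these data alone, how an amine or a carboxylic acid on this phenyl would place the number is also open.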